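The compounds below may be only part of what the source reports. "The series", "measured", "known", "first", "only" and "open" are said of these compounds alone.

In an ADME assay on L929 cells (Mus musculus) for cytotoxicity, read by resazurin assay, with a stated time of 72 h (on this read-out lower numbers stand for stronger inhibition and higher numbers for weaker inhibition), compound 2 `O=C(/C=C/c1ccc2c(c1)B(O)OC2)c1ccccn1` gives > 10 ug/mL, which is a limit of the assay and not a number. Compound 1 `COCOc1cccc(C(=O)/C=C/c2ccc3c(c2)B(O)OC3)c1` gives > 10 ug/mL, which is also a limit. Compound 3 `O=C(/C=C/c1ccc2c(c1)B(O)OC2)c1ccc(OCc2ccccc2)cc1` gives > 10 ug/mL, again a limit. Compound 2 therefore has no exact place among these compounds, and the data show only (the limit of > 10 ug/mL in this assay, at which 3 of the 3 values shown sit).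

Compound 4 `O=C(/C=C/c1ccc2c(c1)B(O)OC2)c1ccccc1O` differs from compound 2 in one place: 2-hydroxyphenyl in place of pyridin-2-yl on a carbonyl carbon. Put simply, 2-hydroxyphenyl stands in place of pyridin-2-yl on a carbonyl carbon.

Among the measured compounds shown here, no measured pair of compounds shows the size of a single change in this assay, so any forecast here is uncertain. The expectation rests on compound 2, whose reading of > 10 ug/mL is a limit. The expected change is a step that the limit leaves unreadable from compound 2 to compound 4, and no step beyond the usual scatter is expected. For compound 4 the estimated value is 14 ug/mL, with an expected range from 5 ug/mL to 40 ug/mL.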

Compound 4, half-maximal inhibitory concentration: > 10 ug/mL
Compound 4: a limit, no number; the forecaster's own chance of this, stated with the estimate: 65%; the middle value does not contradict the limit.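

No step can be read from compound 2 to compound 4 in this assay, because both readings are limits and not numbers: the limit of > 10 ug/mL in this assay, at which 4 of the 4 values shown sit.

The compounds shown leave open what the true value of each one is, and whether 2-hydroxyphenyl in place of pyridin-2-yl changes it at all.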